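This account rests on a few compounds, and the source may have more. Where it says the series, first, only, none or still open, it means among the compounds named here.

Compound 3 (`COc1ccc(/C=C/S(=O)(=O)Nc2ccc(OC)cc2)cc1`) gives 5000 nM in a functional assay on DU-145 cells (Homo sapiens) for cytotoxicity, read by trypan blue exclusion, with a stated time of 96 h (on this read-out higher numbers stand for weaker inhibition and lower numbers for stronger inhibition), and sits level with compound 1 (`COc1ccc(/C=C/S(=O)(=O)Nc2ccc(OC)c(F)c2)cc1`) at 5000 nM and with compound 2 (`COc1ccc(NS(=O)(=O)/C=C/c2ccccc2OC)cc1`) at 5000 nM on the digits available. Compound 4 (`COc1ccc(NS(=O)(=O)/C=C/c2ccc(OC)cc2OC)cc1`) comes next, with methoxy in place of hydrogen on an aromatic carbon. Among the measured compounds shown here, the one measured step (no change at the digits printed from compound 1 to compound 3 (within the scatter)) puts hydrogen in place of fluoro and stays within the scatter. For the measured compounds named here, it is a different exchange, so it bears only loosely, and no measured step covers this one directly. No step beyond the scatter is therefore expected in this assay for this change. The expected step (a 1.3-fold lower number from compound 3 to compound 4 (0.10 log units; within the scatter)) remains an uncertain one. For compound 4 the estimated value is 4000 nM with an expected range (600 nM to 10000 nM).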

Compound 4, half-maximal inhibitory concentration: 15000 nM
Compound 4: the middle estimate sits 3.8-fold (0.57 log units) below what was measured; the measured number lies above the stated range.
By their numbers in this assay, from the lowest: compounds 1, 2 and 3 (each within the scatter of the next); then compound 4.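

In this assay, methoxy in place of hydrogen, ortho to a large group and meta to a methoxy group, weakens inhibition beyond the scatter (a 3.0-fold higher number from compound 3 to compound 4 (0.48 log units; beyond the scatter)), unlike the exchange of fluoro for hydrogen between compound 1 and compound 3 (no change at the digits printed from compound 1 to compound 3 (within the scatter)). The same exchange read from the other monomethoxy compound points the same way (a 3.0-fold higher number from compound 2 to compound 4 (0.48 log units; beyond the scatter)), so this ring tolerates one methoxy better than two in these compounds. No measurement shown gives a reason for this loss. As far as these compounds go, whether an amine or a hydroxyl at this position would also weaken inhibition stays open.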